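Swapping a Phenyl for Chloro on the Fused Ring

The compounds below may be only part of what the source reports. "The series", "measured", "known", "first", "only" and "open" are said of these compounds alone.

Three compounds have so far been measured in a functional assay on HepG2 cells (Homo sapiens) for inhibition, read by MTT assay, with a stated time of 48 h; a higher number here means a weaker inhibitor, a lower number a stronger inhibitor:

Compound 1: `c1ccc(Sc2c(-c3cccc4ccccc34)nc3ccccn23)cc1` gives 9900 nM
Compound 2: `c1ccc(Sc2c(-c3ccccc3)nc3ccc(-c4ccccc4)cn23)cc1` gives 47800 nM
Compound 3: `Cc1ccc(-c2nc3ccc(C)cn3c2Sc2ccccc2)cc1` gives 14600 nM

Among these, compound 2 stands at the highest number, which makes it the weakest inhibitor of the three. The nearest is compound 3, whose number is lower by a margin beyond the usual scatter, and compound 1 lies lower still, also beyond the scatter. All three share the same core with a phenylthio group and a pendant aromatic ring; they differ in what decorates those rings.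

Compound 4, `Clc1ccc2nc(-c3ccccc3)c(Sc3ccccc3)n2c1`, has not yet been tested. Compared with compound 2, it carries chloro in place of phenyl on an aromatic carbon. Going by the values given here, no measured pair shows this exact change, so any expectation rests only on the spread of the three numbers above. Since both compounds without a phenyl at that place, compound 1 and compound 3, gave lower numbers than compound 2, the expected step from compound 2 to compound 4 is a modest move toward a lower number, of about a 2.7-fold lower number from compound 2 to compound 4 (0.42 log units; beyond the scatter). Compound 4 is therefore expected to give roughly 18000 nM, with a plausible range from 6000 nM to 55000 nM.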

Compound 4, half-maximal inhibitory concentration: 15700 nM
For compound 4 the middle estimate is 1.1-fold (0.06 log units) above the measured one; measured number inside the range.
By their numbers in this assay, from the lowest: compounds 1, 3 and 4 (each within the scatter of the next); then compound 2.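

In this assay, going by these compounds alone, putting chloro in place of phenyl on this aromatic carbon gives a 3.0-fold lower number from compound 2 to compound 4 (0.48 log units; beyond the scatter), which is the first direct reading of a change at this position. A whole six-membered aromatic ring gives way to a single chlorine atom, and the compound becomes a stronger inhibitor, so the phenyl is not needed at this place for the inhibition seen here. No measurement available here accounts for this step.

A single step cannot separate the effect of losing the phenyl from that of gaining the chloro. On these data alone, it remains open how a plain hydrogen, a methoxy group or an amine at this place would compare, and whether the same swap would give a similar step with different groups on the rest of the molecule.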